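Exchanging a Phenylsulfonyl for a Phenethylcarbonyl Group

This account rests on a few compounds, and the source may have more. Where it says the series, first, only, none or still open, it means among the compounds named here.

Of the compounds shown here, two sharing one core have been tested in an ADME assay on HEp-2 cells (Homo sapiens) for cytotoxicity, read by CCK-8 assay, with a stated time of 6 days; a lower number here means that less compound is tolerated, a higher number that more compound is tolerated. Compound 1 `NCCNc1cc(N2CCN(c3ccccc3)CC2)nc2ccccc12` carries a phenyl group on an amine nitrogen in a ring, and in this assay compound 1 gives 20800 nM. Compound 2 `NCCNc1cc(N2CCN(S(=O)(=O)c3ccccc3)CC2)nc2ccccc12` carries a phenylsulfonyl group in that place, and in this assay compound 2 gives 20500 nM. Going by the values given here, the step of a 1.0-fold lower number from compound 1 to compound 2 (0.01 log units; within the scatter) shows that this exchange left the read-out essentially unchanged, so compound 2 stands level with compound 1 among the numbers so far.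

Compound 3 `NCCNc1cc(N2CCN(C(=O)CCc3ccccc3)CC2)nc2ccccc12` is not yet measured. It differs from compound 2 in one place: phenethylcarbonyl in place of phenylsulfonyl on an amine nitrogen in a ring. Among the compounds with values here, the only measured step that bears on this change is the one from compound 1 to compound 2, which was within the scatter. Since the new change again alters only the group on that ring nitrogen, a step of no more than the scatter is expected in this assay, in either direction. For compound 3 the estimated half-maximal cytotoxic concentration is 20000 nM, with a range from 8000 nM to 50000 nM, corresponding to an expected step of a 1.0-fold lower number from compound 2 to compound 3 (0.01 log units; within the scatter).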

Compound 3, half-maximal cytotoxic concentration: > 100000 nM
Compound 3 gave a limit, no number; the forecaster's own chance of this, stated with the estimate: 10%; middle value at least 5.0-fold (0.69 log units) away from the limit.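

The earlier pair suggested that the group on this ring nitrogen hardly mattered in this assay, but phenyl and phenylsulfonyl turn out not to mark the whole range of this position. Phenethylcarbonyl in place of phenylsulfonyl gives an at least 4.8-fold higher number from compound 2 to compound 3 (0.68 log units; beyond the scatter), and phenethylcarbonyl in place of phenyl gives an at least 4.8-fold higher number from compound 1 to compound 3 (0.68 log units; beyond the scatter), so more compound is tolerated with this group than with either of the other two, and both steps lie beyond the scatter. The result for compound 3 is a limit and not a number, so these steps give only the least that can be said of the change, and its full size stays unknown: the limit of > 100000 nM in this assay, at which 1 of the 3 values shown sits.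

On these data alone, the three compounds do not separate the carbonyl from the chain that carries the phenyl ring, so it remains open which part of phenethylcarbonyl goes with the higher number. An acetyl group on the same ring nitrogen, or a longer chain ending in an amine or a carboxylic acid, would show whether the effect depends on the carbonyl, the chain or the phenyl ring.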